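Changing the Chain End of Compound 1

The source may report more compounds than this note shows. Statements on the series, on what has been measured and on what is new or still open speak of the compounds shown alone.

Measured so far in a functional assay on A-375 cells (Homo sapiens) for cytotoxicity, read by MTT assay, with a stated time of 72 h (a higher number here means a weaker inhibitor, a lower number a stronger inhibitor), are two compounds:
- Compound 1 `CN(C)CCCCCn1c2c(c3ccccc31)C(=O)c1c[n+]([O-])c3ccccc3c1C2=O` gives 560 nM here
- Compound 2 `CC1(C)O[C@@H](CO)[C@H](Cn2cc(Cn3c4c(c5ccccc53)C(=O)c3c[n+]([O-])c5ccccc5c3C4=O)nn2)O1` gives 190 nM here

Of the two, compound 1 stands at the higher number, a weaker result than compound 2 by a gap beyond the usual scatter. Compound 3 `O=C1c2c[n+]([O-])c3ccccc3c2C(=O)c2c1c1ccccc1n2CCCCN1CCCCC1` has yet to be measured. It differs from compound 1 as follows: piperidin-1-yl in place of (dimethylamino)methyl on a saturated chain carbon, four bonds along the chain from an aromatic nitrogen. Going by the values given here, no measured pair shows this change directly. Compound 2 at 190 nM carries an entirely different chain, so it offers only a loose guide. No step beyond the scatter is therefore expected in this assay, although a small move towards a lower number is possible. The expected change is a 1.2-fold lower number from compound 1 to compound 3 (0.09 log units; within the scatter) and would remain within the scatter. For compound 3 the estimated value is 450 nM in a expected range from 170 nM to 1200 nM when measured.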

Compound 3, half-maximal inhibitory concentration: 190 nM
Compound 3: middle estimate off by 2.4-fold (0.37 log units), on the high side; low and high end bracket the measured number.
By their numbers in this assay, from the lowest: compounds 2 and 3 (each within the scatter of the next); then compound 1.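

In this assay, piperidin-1-yl in place of (dimethylamino)methyl on a saturated chain carbon, four bonds along the chain from an aromatic nitrogen, gives a 2.9-fold lower number from compound 1 to compound 3 (0.47 log units; beyond the scatter). Going by these compounds alone, this is the first comparison in which only the chain end differs, and it shows that the number responds to a change at this position by more than the usual scatter, with one six-membered non-aromatic ring entering where no ring leaves. Nothing available explains why the number moves in this direction.

Within the data shown here, the single step does not separate the ring from the way the chain is built, as the same difference also reads 4-(dimethylamino)butyl to 3-(piperidin-1-yl)propyl, so the effect of a dimethylamino group on the chain of compound 3, or of piperidin-1-yl on the longer chain of compound 1, remains open. As far as these compounds go, how other cyclic amines at the chain end, such as pyrrolidin-1-yl or morpholin-4-yl, would read in this assay also remains unknown from these compounds.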